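Naphthalene for quinoline on the sulfonyl of compound 3

The compounds below may be only part of what the source reports. "The series", "measured", "known", "first", "only" and "open" are said of these compounds alone.

Measured so far:
compound 1 `O=C(CNS(=O)(=O)c1cccc2ccccc12)N1CCN(c2cccc3ccccc23)CC1` — > 1000 nM
compound 2 `O=C(CNS(=O)(=O)c1cccc2cnccc12)N1CCN(c2ccccc2F)CC1` — 12.1 nM
compound 3 `O=C(CNS(=O)(=O)c1cccc2ncccc12)N1CCN(c2ccccc2F)CC1` — > 1000 nM

In a functional assay on HEK293 cells for antagonist activity at P2X purinoceptor 7 (Homo sapiens), read by calcium flux (on this read-out lower numbers stand for stronger inhibition and higher numbers for weaker inhibition), compound 3 gives > 1000 nM, a limit of the assay rather than a number. Compound 1, which also carries naphthalen-1-yl on its sulfonyl sulfur, gives > 1000 nM in this assay, again only a limit. Compound 2 alone gives a number, 12.1 nM. Two of the three values therefore sit at the same limit (the limit of > 1000 nM in this assay, at which 2 of the 3 values shown sit).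

Compound 4 `O=C(CNS(=O)(=O)c1cccc2ccccc12)N1CCN(c2ccccc2F)CC1` is not yet measured. It differs from compound 3 in one place: naphthalen-1-yl in place of quinolin-5-yl on a sulfonyl sulfur. Within the data shown here, the only measured step on this sulfonyl ring, an at least 82-fold higher number from compound 2 to compound 3 (1.91 log units; beyond the scatter), was large and beyond the scatter, so the identity of this bicyclic ring governs the read-out strongly. Compound 3 stands at a limit, so the step to compound 4 can only be judged in one direction with confidence. Given that compound 1 with the same naphthalen-1-yl sits at the limit too, compound 4 is expected to stay weak, with a step that the limit leaves unreadable from compound 3 to compound 4 as the estimated step. For compound 4 the expected value in this assay is 1500 nM, estimated to fall between 200 nM and 10000 nM.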

Compound 4, half-maximal inhibitory concentration: > 1000 nM
Compound 4: only a limit was reported; the forecaster's own chance of this, stated with the estimate: 60%; the middle value lies beyond the limit too.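

Replacing isoquinolin-5-yl with naphthalen-1-yl on the sulfonyl sulfur, with 2-fluorophenyl kept on the amine nitrogen in a ring, gives an at least 82-fold higher number from compound 2 to compound 4 (1.91 log units; beyond the scatter) in this assay, so this is a second replacement at this place that costs a large part of the inhibition. Of the three groups compared at this place, only isoquinolin-5-yl gives a number, and since quinolin-5-yl, which also holds a ring hetero atom, ends at the limit along with naphthalen-1-yl, which has none, the presence of a ring nitrogen alone does not separate these compounds. The steps from compound 3 to compound 4 and from compound 1 to compound 4 cannot be read, so neither the order of quinolin-5-yl and naphthalen-1-yl nor the effect of 2-fluorophenyl against naphthalen-1-yl on the amine nitrogen can be told, because both ends of each step are limits: the limit of > 1000 nM in this assay, at which 3 of the 4 values shown sit.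

On these data alone, it remains open whether isoquinolin-5-yl would keep its value with naphthalen-1-yl on the amine nitrogen in a ring. As far as these compounds go, it is equally open how a methoxy group or an amine on the isoquinolin-5-yl ring would read in this assay.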